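A few compounds are considered here, and "the series" means these few. Any claim that something is new, unique, unknown or untested is made for them only; others in the source may bear on it.

Measured compounds:
Compound 1 `COc1ccc(C2=C(c3cc(OC)c(OC)c(OC)c3)C(=O)CC2C)cc1C(=O)O` gives > 100 ug/mL in an ADME assay on ECV-304 cells (Homo sapiens) for cytotoxicity, read by MTT assay, with a stated time of 72 h; on this read-out lower numbers stand for stronger inhibition and higher numbers for weaker inhibition; this is a limit of the assay, not a number.
Compound 2 `COc1ccc(C2=C(c3cc(OC)c(OC)c(OC)c3)CC(O)C2=O)cc1N` gives > 100 ug/mL; again a limit.
Compound 3 `CC(=O)OC1C/C(=N/O)C(c2ccccc2)=C1c1ccccc1` gives > 100 ug/mL; again a limit.

Compound 3 therefore has no measured number in this assay, only a limit, and the same holds for the other two compounds: all three sit at the limit of > 100 ug/mL in this assay, at which 3 of the 3 values shown sit. No pair of these compounds differs in one place, so no measured step is available, and the numbers show only that none of the three reached a measurable effect.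

Compound 4 `O/N=C1/CC(O)C(c2ccccc2)=C1c1ccccc1` is not yet measured in this assay. It differs from compound 3 by hydrogen in place of acetyl on an oxygen on a saturated carbon, so the acetoxy group of compound 3 becomes a hydroxy group in compound 4. Among the measured compounds shown here, with no measured step to lean on, the expectation rests on compound 3 alone, whose reading of > 100 ug/mL is a limit.

The step that the limit leaves unreadable from compound 3 to compound 4 is expected to be none beyond the usual scatter, since compound 3 and its companions all sit at the limit. Compound 4 is therefore estimated at 150 ug/mL, within a range of 60 ug/mL to 400 ug/mL, with a high chance that the assay again reports only a limit.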

Compound 4, half-maximal inhibitory concentration: > 100 ug/mL
Compound 4 gave a limit, no number (the forecaster's own chance of this, stated with the estimate: 80%); the middle value lies beyond the limit too.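

No step can be read from compound 3 to compound 4, the change from acetoxy to hydroxy, because both readings are limits of the assay and not numbers: the limit of > 100 ug/mL in this assay, at which 4 of the 4 values shown sit.

The compounds shown leave open whether that change alters the result in this assay at all, and at what concentration, if any, any of the four would show an effect.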